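The compounds below may be only part of what the source reports. "The series", "measured", "known", "first", "only" and "open" are said of these compounds alone.

Compound 3 `N#Cc1c(-c2ccc3c(ccn3[C@H]3CC[C@H](O)CC3)c2)ccn2c(CC(F)(F)F)cnc12`: 330 nM
Compound 2 `N#Cc1c(-c2cc(Cl)c3[nH]ccc3c2)ccn2c(CC(F)(F)F)cnc12`: 320 nM
Compound 1 `N#Cc1c(-c2ccc3c(ccn3CC3CC3)c2)ccn2c(CC(F)(F)F)cnc12`: 190 nM

All three were measured in a functional assay on CHO cells for agonist activity at metabotropic glutamate receptor 2 (Homo sapiens), read by GTPgammaS binding; on this read-out higher numbers stand for an effect only at larger amounts of compound and lower numbers for an effect already at smaller amounts. Going by the values given here, compound 3 gives the highest of these three numbers, but its gaps to compound 2 and to compound 1 both lie within the usual scatter, and the only step between two compounds differing in one place, a 1.7-fold higher number from compound 1 to compound 3 (0.24 log units; within the scatter), also stays within the scatter.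

Compound 4 `O[C@H]1CC[C@H](n2ccc3cc(-c4ccn5c(CC(F)(F)F)cnc5c4Cl)ccc32)CC1` differs from compound 3 by chloro in place of cyano on an aromatic carbon. Among the compounds with values here, no measured pair shows this exchange: the one recorded step changes the group on the aromatic nitrogen instead, so it does not bear on it. With nothing pointing either way, no step beyond the scatter is expected in this assay. Compound 4 is therefore expected near 400 nM, between 100 nM and 1600 nM. The expected step is a 1.2-fold higher number from compound 3 to compound 4 (0.08 log units; within the scatter).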

Compound 4, half-maximal effective concentration: 160 nM
Estimate against measurement, compound 4: 2.5-fold (0.40 log units) above; the range from low to high includes it.
By their numbers in this assay, from the lowest: compounds 4, 1, 2 and 3 (each within the scatter of the next, the first and the last beyond it).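

The position on the aromatic carbon of the core now has its first reading: in this assay, chloro in place of cyano gives a 2.1-fold lower number from compound 3 to compound 4 (0.31 log units; beyond the scatter), a modest step just beyond the scatter. The nitrile is therefore not needed for activity here, and a single chlorine atom, with no hydrogen-bond acceptor, serves at least as well. Nothing measured here explains this step.

From the compounds shown here alone, whether methyl, bromo or an amine at this position would give a lower number remains open. So does whether chloro gives a similar step with cyclopropylmethyl on the aromatic nitrogen.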